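A Thiocarbonyl Substituent Swap Leading to Compound 4

The source may hold more compounds than are shown below. What is called first, only, known or untested is meant among the compounds shown, and "the series" means these compounds.

Compound 3 `CN(C(=S)SCc1ccc(C(=O)Nc2ccccc2N)cc1)c1cccnc1` gives 82.5% in a functional assay on MGC-803 cells (Homo sapiens) for antiproliferative activity, read by CCK-8 assay, with a stated time of 72 h, tested at 8 uM (on this read-out lower numbers stand for a weaker effect and higher numbers for a stronger effect at the one concentration tested), the highest of the three numbers recorded. Compound 1 `Nc1ccccc1NC(=O)c1ccc(CSC(=S)N2CCN(c3ccc(F)cc3)CC2)cc1` gives 48.7% and compound 2 `Nc1ccccc1NC(=O)c1ccc(CSC(=S)N2CCN(Cc3ccccc3)CC2)cc1` gives 19.7%, both lying beyond the scatter below compound 3. Compound 4 `CN1CCN(C(=S)SCc2ccc(C(=O)Nc3ccccc3N)cc2)CC1` differs from compound 3 in one place: 4-methylpiperazin-1-yl in place of methyl(pyridin-3-yl)amino on a thiocarbonyl carbon. Among the compounds with values here, the only measured step touching this region is a number 29 percentage points lower from compound 1 to compound 2 (beyond the scatter), where benzyl in place of 4-fluorophenyl on an amine nitrogen in a ring lowered the read-out. By analogy, replacing methyl(pyridin-3-yl)amino with the non-aromatic 4-methylpiperazin-1-yl ring is expected to lower the read-out, with an expected step of a number 37.5 percentage points lower from compound 3 to compound 4 (beyond the scatter). Compound 4 is therefore estimated at 45%, within an expected range from 15% to 75%.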

Compound 4, a percentage reported as inhibition, at one concentration (the size of the read-out at that concentration, not a potency): 84.4%
Compound 4: middle estimate off by 39.4 percentage points, on the low side, and the stated range ends below it.
By their numbers in this assay, from the lowest: compound 2; then compound 1; then compounds 3 and 4 (each within the scatter of the next).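

With a number 1.9 percentage points higher from compound 3 to compound 4 (within the scatter) in this assay, the thiocarbonyl carbon accepts 4-methylpiperazin-1-yl in place of methyl(pyridin-3-yl)amino, so among these compounds the aromatic ring of the leaving group is not needed for the read-out. On the amine nitrogen in the ring, methyl in place of 4-fluorophenyl gives a number 35.7 percentage points higher from compound 1 to compound 4 (beyond the scatter) and hydrogen in place of phenyl on the chain carbon gives a number 64.7 percentage points higher from compound 2 to compound 4 (beyond the scatter), so aromatic groups there go with lower numbers in this set. Nothing measured here accounts for these differences. Still open, from the compounds shown here alone, is whether ethyl or hydrogen on that ring nitrogen would hold the read-out, and whether a morpholine ring would do so on the thiocarbonyl carbon.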